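The compounds below may be only part of what the source reports. "The series", "measured", "known", "first", "only" and "open" are said of these compounds alone.

Of the compounds shown here, three sharing one core have been measured in a functional assay on the whole organism (blood, strain albino) with Mus musculus as the target, with stated times of 6 days and 3 h, at a dose of 1 mmol/kg by the oral route; on this read-out lower numbers stand for less inhibition and higher numbers for more inhibition at the one dose given (going by the name of the read-out). Compound 1, `CCCCN1C(=O)CCN(S(=O)(=O)c2ccc(-n3nc(C(=O)O)cc3C)cc2)C1=S`, gives 2% in this assay. Compound 2, `CCN1C(=O)CCN(S(=O)(=O)c2ccc(-n3nc(C)cc3C)cc2)C1=S`, gives 4%, and compound 3, `Cc1cc(C)n(-c2ccc(S(=O)(=O)N3CCC(=O)N(C4CCCCC4)C3=S)cc2)n1`, gives 4%. Compound 3 thus stands level with compound 2 at the digits shown, and these two together hold the highest numbers of the three; compound 1 sits within the scatter of repeated measurements of them. For the measured compounds named here, the one step between compounds that differ in a single place, no change at the digits printed from compound 2 to compound 3 (within the scatter), placed cyclohexyl in place of ethyl on an amide-type nitrogen in a ring and brought no change beyond the scatter.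

Compound 4, `CCCCN1C(=O)CCN(S(=O)(=O)c2ccc(-n3nc(C)cc3C)cc2)C1=S`, has not yet been measured. It differs from compound 3 in one place: butyl in place of cyclohexyl on an amide-type nitrogen in a ring. Going by the values given here, the only measured step that bears on this change is no change at the digits printed from compound 2 to compound 3 (within the scatter), which swapped groups on the same nitrogen without moving the number. Compound 1, which also carries butyl on that nitrogen, shows a number in the same low region. Compound 4 is therefore expected to show no step beyond the scatter, a number 1 percentage points lower from compound 3 to compound 4 (within the scatter), and an estimated value of 3%, with a range from 0% to 12%.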

Compound 4, a percentage reported as inhibition, in the whole organism at one dose (the size of the read-out at that dose, not a potency): 1%
Estimate against measurement, compound 4: 2 percentage points above; the measured number falls inside the stated range.
By their numbers in this assay, from the lowest: compounds 4, 1, 2 and 3 (each within the scatter of the next).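

In this assay, butyl in place of cyclohexyl on the amide-type nitrogen in a ring gives a number 3 percentage points lower from compound 3 to compound 4 (within the scatter) and thus shows that an open chain with no ring cannot be told apart from the six-membered carbon ring at this position. Compound 4 also gives a second reading at the same nitrogen, since going from ethyl to butyl gives a number 3 percentage points lower from compound 2 to compound 4 (within the scatter) and so the length of the chain makes no measurable difference across this pair, just as the change of ring for chain makes none. For the compounds shown here, compound 4 adds a comparison at another place as well, where methyl in place of carboxy on an aromatic carbon gives a number 1 percentage points lower from compound 1 to compound 4 (within the scatter) and so the first single-place reading of the carboxy group shows no difference either.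

Nothing measured here offers an explanation for these readings. Still open, on these data alone, is whether a different kind of group on that nitrogen, such as a benzyl group or a chain ending in an amine, would move the number beyond the scatter, and whether an ester or an amide in place of the carboxy group would do so at the aromatic carbon.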